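This account rests on a few compounds, and the source may have more. Where it says the series, first, only, none or still open, it means among the compounds named here.

Working notes on the series in a functional assay on PC-3 cells (Homo sapiens) for cytotoxicity, read by MTT assay, with a stated time of 72 h; on this read-out lower numbers stand for stronger inhibition and higher numbers for weaker inhibition.

Compound 1 `CC1=C(/C=C/C(=O)/C=C/c2ccc(C(F)(F)F)cc2)C(C)(C)CCC1` gives 12000 nM in this assay. Compound 2 `CC1=C(/C=C/C(=O)/C=C/c2ccc(F)cc2)C(C)(C)CCC1` carries the change fluoro in place of trifluoromethyl on an aromatic carbon and gives 25800 nM; the step is a 2.2-fold higher number from compound 1 to compound 2 (0.33 log units; beyond the scatter). Compound 3 `CC1=CCCC(C)(C)C1/C=C/C(=O)/C=C/c1ccccc1C(F)(F)F` has the same atoms as compound 1 joined differently; the difference between the two cores is not broken down here. In this assay compound 3 gives 19000 nM, a number that sits within the scatter of both compound 1 and compound 2, so no order among the three is claimed.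

Compound 4 `CC1=CCCC(C)(C)C1/C=C/C(=O)/C=C/c1ccccc1F` is not yet measured. It differs from compound 3 by fluoro in place of trifluoromethyl on an aromatic carbon. This is the same kind of change as that from compound 1 to compound 2, but the place is not identical: in the earlier pair the substituent sits para to a large group, whereas in compound 4 it sits ortho to a large group. The change has been seen only once in the series, and only at the para position, so the carry-over to the ortho position rests on a single precedent.

On that basis the step from compound 3 to compound 4 is expected to be a 2.1-fold higher number from compound 3 to compound 4 (0.32 log units; beyond the scatter), of the same order as the earlier step, because the prior change gave a 2.2-fold higher number from compound 1 to compound 2 (0.33 log units; beyond the scatter). The estimate for compound 4 in this assay is 40000 nM, with the expected range running from 17000 nM to 95000 nM.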

Compound 4, half-maximal inhibitory concentration: 4800 nM
Beside the measured number, compound 4's estimate is 8.3-fold (0.92 log units) above it, outside the stated range (below it).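

With the group ortho to a large group, fluoro in place of trifluoromethyl on an aromatic carbon gives a 4.0-fold lower number from compound 3 to compound 4 (0.60 log units; beyond the scatter) in this assay. The change therefore does not carry over from one pair to the other in direction or in size, and its outcome in this series depends on the pair in which it is made: the same change on two cores in this assay, a 2.2-fold higher number (0.33 log units; beyond the scatter) from compound 1 to compound 2 and a 4.0-fold lower number (0.60 log units; beyond the scatter) from compound 3 to compound 4, 8.5-fold (0.93 log units) apart, beyond the scatter of two such steps. This does not show whether the core or the place of the substituent accounts for the difference, since the two pairs differ in both, and two pairs alone give no rule for how the change will behave on any further compound.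

The compounds shown leave open what a pair with the core of compound 1 and the group ortho to a large group would give, and what the matching pair on the core of compound 3 would give with the group at the place it holds in compound 1, which is the comparison needed to separate core from place. They also leave open whether the lower number of compound 4 is particular to fluoro or extends to other replacements for trifluoromethyl at that place, such as chloro, methoxy or a nitrile, or to plain hydrogen.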